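Extending the ether chain of compound 3 toward a dimethylamide

The compounds below may be only part of what the source reports. "The series", "measured", "known", "first", "only" and "open" are said of these compounds alone.

Of the compounds shown here, three have been measured in an assay on isolated protein for binding affinity to leukotriene B4 receptor 1 (Homo sapiens), tested at 1 uM; a lower number here means less inhibition, a higher number more inhibition at the concentration tested (going by the name of the read-out). Compound 1 `CC(=O)c1cc(CC2CO2)c(OCCCCC#N)cc1O` gives 24%, compound 2 `CC(=O)c1cc(C=O)c(OCCCCC#N)cc1O` gives 3%, and compound 3 `CCc1cc(C(C)=O)c(O)cc1OCCCC(C)(C)C#N` gives 46%, the highest of the three; it sits above compound 1 and furthest above compound 2. The one step shown between measured compounds runs a number 21 percentage points lower from compound 1 to compound 2 (beyond the scatter), a change on the aromatic core, not on the ether chain.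

Compound 4 `CCc1cc(C(C)=O)c(O)cc1OCCCCCCC(=O)N(C)C` differs from compound 3 by 3-(dimethylcarbamoyl)propyl in place of 1-cyano-1-methylethyl on a saturated chain carbon, three bonds along the chain from an oxygen on an aromatic ring. Within the data shown here, no measured pair alters the chain end, so the step from compound 1 to compound 2 does not bear on this change, and no precedent exists for how this assay responds to it. Compound 4 is therefore expected to show a value near that of compound 3, with a wide range, so the estimated step of a number 11 percentage points lower from compound 3 to compound 4 (beyond the scatter) is modest. For compound 4 the expected value is 35%, with a range from 5% to 65%.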

Compound 4, a percentage reported as inhibition, at one concentration (the size of the read-out at that concentration, not a potency): 61%
For compound 4 the middle estimate is 26 percentage points below the measured one; low and high end bracket the measured number.
By their numbers in this assay, from the lowest: compound 2; then compound 1; then compound 3; then compound 4.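

In this assay, putting 3-(dimethylcarbamoyl)propyl in place of 1-cyano-1-methylethyl on the saturated chain carbon gives a number 15 percentage points higher from compound 3 to compound 4 (beyond the scatter) on an otherwise shared core. Among these compounds, this is the first measured step on the ether chain rather than on the aromatic core, and it shows that this place responds to change and that the number does not depend on keeping the nitrile. Nothing at hand accounts for the rise.

The step replaces the branching, the nitrile and the chain length all at once, and the compounds shown do not separate these three changes. On these data alone, whether a carboxylic acid, a primary amide or a still longer chain in that place would hold the number seen for compound 4 remains open.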